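The source may report more compounds than this note shows. Statements on the series, on what has been measured and on what is new or still open speak of the compounds shown alone.

Compound 1: `Nc1ncnc2c1ncn2CC(O)C(=O)OCCO`, > 400 ug/mL in a functional assay on PRK cells (Oryctolagus cuniculus) for cytotoxicity; on this read-out lower numbers stand for higher toxicity in this test and higher numbers for lower toxicity in this test
Compound 2: `CCCCOC(=O)C(O)Cn1cnc2c(N)ncnc21`, 200 ug/mL in this assay

In this assay, going by the values given here, compound 2 gives 200 ug/mL, the only number among the two values shown. Compound 1 reaches only a limit of this assay, > 400 ug/mL, and that value is a limit rather than a number. Among the compounds with values here, the one measured step, an at least 2.0-fold lower number from compound 1 to compound 2 (0.30 log units; that floor lies within the scatter), therefore starts from the limit described in the limit of > 400 ug/mL in this assay, at which 1 of the 2 values shown sits, and ends at a number, and its floor lies within the scatter, so its true size is not known.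

Compound 3, `CC(C)OC(=O)C(O)Cn1cnc2c(N)ncnc21`, remains to be measured. It differs from compound 2 as follows: isopropyl in place of butyl on an oxygen next to a carbonyl group. Butyl leaves and isopropyl enters on an oxygen next to a carbonyl group. The step from compound 1 to compound 2 is the only measured one, and it concerns a different place on the molecule, so it offers little direct guidance here. One expects no step beyond the scatter, a 1.5-fold higher number from compound 2 to compound 3 (0.18 log units; within the scatter), with some chance that compound 3 returns to the limit. Compound 3 is estimated at 300 ug/mL, with a range from 150 ug/mL to 400 ug/mL.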

Compound 3, minimum cytotoxic concentration: > 400 ug/mL
Compound 3 gave a limit, no number; the forecaster's own chance of this, stated with the estimate: 40%; middle value at least 1.3-fold (0.12 log units) away from the limit.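

Going by these compounds alone, with the hydroxy group unchanged, isopropyl in place of butyl on an oxygen next to a carbonyl group gives an at least 2.0-fold higher number from compound 2 to compound 3 (0.30 log units; that floor lies within the scatter) in this assay and this is the first reading for this position, separate from the earlier step at the chain carbon; its floor lies within the scatter, so it does not establish a real change, and its true size remains unknown. Within the data shown here, compound 2 is now the only compound with a number, while the other two compounds stand at a limit of the assay and not at a number: the limit of > 400 ug/mL in this assay, at which 2 of the 3 values shown sit. The step from compound 1 to compound 3 cannot be read: both of its values are limits.

On these data alone, it remains open whether the number of compound 2 goes with the carbon count of the butyl group or with its unbranched shape, and a straight propyl group on the same oxygen would help to separate these two readings. Also open, as far as these compounds go, is how a longer chain such as hexyl, an amine at the end of the chain, or a carboxylic acid in place of the ester would read in this assay.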